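Chain length on the shared core and growth inhibition

The source may report more compounds than this note shows. Statements on the series, on what has been measured and on what is new or still open speak of the compounds shown alone.

In a functional assay on L1210 cells (Mus musculus) (on this read-out higher numbers stand for weaker inhibition and lower numbers for stronger inhibition), compound 2 `CCc1cn([C@H]2C[C@@H]3OP(=O)(O)OC[C@H]3O2)c(=O)[nH]c1=O` gives 55 ug/mL, the lowest of the two numbers measured, while compound 1 `CCCCCCCCc1cn([C@H]2C[C@H](O)[C@@H](CO)O2)c(=O)[nH]c1=O` gives 66 ug/mL, within the scatter of it. Compound 3 `CCCCCCc1cn([C@H]2C[C@@H]3OP(=O)(O)OC[C@H]3O2)c(=O)[nH]c1=O` is recorded only as a limit of the assay, > 500 ug/mL (the limit of > 500 ug/mL in this assay, at which 1 of the 3 values shown sits). The unmeasured compound 4 `CCCc1cn([C@H]2C[C@@H]3OP(=O)(O)OC[C@H]3O2)c(=O)[nH]c1=O` differs from compound 2 by methyl in place of hydrogen on a saturated chain carbon, two bonds along the chain from an aromatic carbon. Among the measured compounds shown here, the one measured step that bears on this is an at least 9.0-fold higher number from compound 2 to compound 3 (0.95 log units; beyond the scatter), a larger group entering on the saturated chain carbon two bonds along the chain from an aromatic carbon, which weakened inhibition beyond the scatter. The smaller methyl is expected to move the number the same way but by less, so a step of about a 2.0-fold higher number from compound 2 to compound 4 (0.30 log units; within the scatter) is anticipated. Compound 4 is therefore estimated at 110 ug/mL, with a range from 45 ug/mL to 300 ug/mL.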

Compound 4, concentration for 50% inhibition: > 500 ug/mL
Compound 4 gave a limit, no number (the forecaster's own chance of this, stated with the estimate: 10%); middle value at least 4.5-fold (0.65 log units) away from the limit.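

Methyl alone, on a saturated chain carbon, two bonds along the chain from an aromatic carbon, already gives an at least 9.0-fold higher number from compound 2 to compound 4 (0.95 log units; beyond the scatter), so weakening in this assay on the shared core does not require an addition as large as butyl. Compound 3 and compound 4 both stand at a limit rather than a number, so the step between them cannot be read and no ranking of propyl against hexyl follows: the limit of > 500 ug/mL in this assay, at which 2 of the 4 values shown sit.

Open, as far as these compounds go, is how a chain shorter than ethyl, such as methyl, reads on the shared core. Also open, from the compounds shown here alone, is whether a branched isopropyl group or a propyl chain ending in an amine would stay near compound 2 at 55 ug/mL.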